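Diamine Side Arm Gives Way to Benzyl(propyl)amino

The source may hold more compounds than are shown below. What is called first, only, known or untested is meant among the compounds shown, and "the series" means these compounds.

Of the compounds shown here, three sharing one core have been measured in an assay on HEK293 cells for inhibition of Steryl-sulfatase (Homo sapiens), tested at 0.1 uM; on this read-out higher numbers stand for a stronger effect at the one concentration tested and lower numbers for a weaker effect. Compound 1 `CN(C)CCN(Cc1ccccc1)c1cccc(C(=O)N2CCc3ccc(OS(N)(=O)=O)cc3C2)c1` gives 0%, compound 2 `CCN(Cc1ccc(F)cc1)c1cccc(C(=O)N2CCc3ccc(OS(N)(=O)=O)cc3C2)c1` gives 10.9%, and compound 3 `CN(C)CCN(CCN(C)C)c1cccc(C(=O)N2CCc3ccc(OS(N)(=O)=O)cc3C2)c1` gives 0%. Compound 3 therefore sits level with compound 1 at the digits shown, the two together forming the lowest pair of the three, while compound 2 stands higher.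

Compound 4 `CCCN(Cc1ccccc1)c1cccc(C(=O)N2CCc3ccc(OS(N)(=O)=O)cc3C2)c1` is yet to be tested. Against compound 3 it differs in one place: benzyl(propyl)amino in place of bis(2-(dimethylamino)ethyl)amino on an aromatic carbon. Within the data shown here, two measured steps bear on this. One, no change at the digits printed from compound 1 to compound 3 (within the scatter), shows that exchanging phenyl for (dimethylamino)methyl left the read-out unmoved. Among the measured compounds shown here, the other, a number 10.9 percentage points lower from compound 2 to compound 3 (beyond the scatter), shows a modest loss when an aryl-bearing amine was replaced by the diamine; compound 4 roughly reverses that move, though no step between compound 1 and compound 4 has been measured. Compound 4 is therefore expected to show a small rise, a number 8 percentage points higher from compound 3 to compound 4 (within the scatter), to an estimated 8% within a range from 0% to 20%.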

Compound 4, a percentage reported as inhibition, at one concentration (the size of the read-out at that concentration, not a potency): 23.1%
Beside the measured number, compound 4's estimate is 15.1 percentage points below it, and the stated range ends below it.
By their numbers in this assay, from the lowest: compounds 1 and 3 (each within the scatter of the next); then compound 2; then compound 4.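

In this assay, the amine on this aromatic carbon proves able to move the read-out: a number 23.1 percentage points higher from compound 3 to compound 4 (beyond the scatter) with benzyl(propyl)amino replacing bis(2-(dimethylamino)ethyl)amino, and a number 23.1 percentage points higher from compound 1 to compound 4 (beyond the scatter) with methyl replacing dimethylamino on the side chain while the benzyl group stays, so compound 4 now stands highest of the four. Among the benzyl-bearing amines, a number 12.2 percentage points higher from compound 2 to compound 4 (beyond the scatter) with benzyl(propyl)amino in place of ethyl(4-fluorobenzyl)amino, showing that the number still changes when no dimethylamino group is present in either compound. No evidence is available on what lies behind these steps.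

The step from compound 2 to compound 4 changes the chain and the ring fluorine together, so the share of each stays unresolved. From the compounds shown here alone, whether a butyl chain on this nitrogen, or a 4-fluorobenzyl group paired with propyl, would raise the number further also remains open.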